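This account rests on a few compounds, and the source may have more. Where it says the series, first, only, none or still open, it means among the compounds named here.

Measured in a functional assay on U-87MG ATCC cells (Homo sapiens) for inhibition; a lower number here means a stronger inhibitor, a higher number a weaker inhibitor:
Compound 1 `COc1cc(/C=C/C(=O)c2cccc(N)c2)ccc1O`: 7.71 ug/mL
Compound 2 `COc1cc(/C=C/C(=O)c2cccc(NC(=O)c3ccc(Cl)c(Cl)c3)c2)ccc1O`: 29.5 ug/mL
Compound 3 `COc1cc(/C=C/C(=O)c2cccc(NC(=O)C(C)C)c2)ccc1O`: 8.31 ug/mL

Compound 3 gives 8.31 ug/mL. Its nearest neighbour is reached by a 1.1-fold higher number from compound 1 to compound 3 (0.03 log units; within the scatter), and its furthest by a 3.5-fold lower number from compound 2 to compound 3 (0.55 log units; beyond the scatter). Compound 4 `COC(=O)C(=O)Nc1cccc(C(=O)/C=C/c2ccc(O)c(OC)c2)c1` has methoxycarbonyl in place of isopropyl on a carbonyl carbon. Among the measured compounds shown here, no measured step makes this exact change. The closest evidence is a 1.1-fold higher number from compound 1 to compound 3 (0.03 log units; within the scatter), with the ring-free group, against a 3.8-fold higher number from compound 1 to compound 2 (0.58 log units; beyond the scatter), with the ring-bearing one. Compound 4 also keeps a ring-free group, so a small step is expected in this assay, with no clear direction. The estimated step is a 1.2-fold higher number from compound 3 to compound 4 (0.08 log units; within the scatter), not expected to pass the scatter. For compound 4 the expected value is 10 ug/mL. The estimated range runs from 5 ug/mL to 22 ug/mL.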

Compound 4, half-maximal inhibitory concentration: 12.2 ug/mL
Compound 4: the middle estimate sits 1.2-fold (0.09 log units) below what was measured; the range from low to high includes it.
By their numbers in this assay, from the lowest: compounds 1, 3 and 4 (each within the scatter of the next); then compound 2.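

In this assay, methoxycarbonyl on the carbonyl carbon gives a 1.5-fold higher number from compound 3 to compound 4 (0.17 log units; within the scatter), and (methoxycarbonyl)carbonyl on the nitrogen gives a 1.6-fold higher number from compound 1 to compound 4 (0.20 log units; within the scatter), so a second ring-free group also stays within the scatter of the unacylated amine. Methoxycarbonyl in place of 3,4-dichlorophenyl gives a 2.4-fold lower number from compound 2 to compound 4 (0.38 log units; beyond the scatter), which leaves compound 2 as the only one of the four apart from the others. Nothing available here offers an explanation for these numbers. The compounds shown leave open whether a plain phenyl on that carbonyl carbon would track the 3,4-dichlorophenyl or the ring-free groups. They also leave open how a carboxylic acid in place of methoxycarbonyl would read.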